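Sulfamoyl to methylsulfonyl on the benzylamide series

The source may report more compounds than this note shows. Statements on the series, on what has been measured and on what is new or still open speak of the compounds shown alone.

Measured so far:
Compound 1 `CC(NC(=O)c1ccc(C(C)(C)C)cc1)c1ccc(C(=O)O)cc1`: 76 nM
Compound 2 `CC(C)(C)c1ccc(C(=O)NCc2ccc(S(N)(=O)=O)cc2)cc1`: 1400 nM
Compound 3 `O=C(O)c1ccc(CNC(=O)c2ccc(-c3ccccc3)cc2)cc1`: 440 nM

All three numbers come from an assay on HeLa cells with Bile acid receptor (Homo sapiens) as the target, read by a luciferase reporter, with a stated time of 24 h; on this read-out higher numbers stand for an effect only at larger amounts of compound and lower numbers for an effect already at smaller amounts. Compound 2 stands at the top of the three numbers: compound 3 is the nearer of the other two, with a lower number that already lies beyond the scatter, and compound 1 is the furthest, with a lower number well beyond the scatter. Among the compounds with values here, no pair among the three differs in only one place, so no single step can be read off from the measured set.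

Compound 4 `CC(C)(C)c1ccc(C(=O)NCc2ccc(S(C)(=O)=O)cc2)cc1` is the untested analogue of compound 2. The change is methyl in place of amino on a sulfonyl sulfur. Nothing in the measured set tests this change directly; the measured differences involve the acid and the linker and do not isolate the sulfonyl substituent. On that basis no step beyond the scatter is expected in this assay, with some room for a drift in either direction. The estimate for compound 4 is 1500 nM, range 400 nM to 6000 nM, which would mean an expected step of a 1.1-fold higher number from compound 2 to compound 4 (0.03 log units; within the scatter).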

Compound 4, half-maximal effective concentration: 3800 nM
Compound 4: middle estimate off by 2.5-fold (0.40 log units), on the low side; low and high end bracket the measured number.
By their numbers in this assay, from the lowest: compound 1; then compound 3; then compound 2; then compound 4.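

Within the data shown here, on the sulfonyl sulfur of this benzylamide, the substituent is not a silent position in this assay: methyl in place of amino gives a 2.7-fold higher number from compound 2 to compound 4 (0.43 log units; beyond the scatter), a modest step but one beyond the scatter, and the only single-place comparison so far. The amino group leaves with its hydrogen-bond donor and the methyl group brings none, but this single pair cannot show whether that donor is what matters. No measurement shown here accounts for the step.

On these data alone, it remains open whether an ethyl group on the same sulfur extends the rise seen with methyl. As far as these compounds go, it also remains open whether a methylamino group, which keeps a nitrogen on the sulfur, reads closer to compound 2 or to compound 4.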